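Ethyl ester with furan-2-yl: expected displacement at one concentration

The source may hold more compounds than are shown below. What is called first, only, known or untested is meant among the compounds shown, and "the series" means these compounds.

Three compounds of the shared core have been run in an assay on cells for displacement of a labelled ligand from adenosine receptor A1 (Homo sapiens), with a stated time of 60 min, tested at 1 uM; on this read-out higher numbers stand for more inhibition at the one concentration tested (going by the name of the read-out) and lower numbers for less inhibition. Compound 1 `CC1=C(C(=O)OC(C)C)[C@H](c2ccco2)N/C(=N/C#N)N1` gives 18%, compound 2 `CCOC(=O)C1=C(C)N/C(=N\C#N)NC1c1ccsc1` gives 29%, and compound 3 `CC1=C(C(=O)OC(C)C)C(c2ccccc2)N/C(=N/C#N)N1` gives 20%. Compound 2 holds the highest of the three numbers; the gap to compound 3 lies within the scatter, the gap to compound 1 lies beyond it. Compound 4 `CCOC(=O)C1=C(C)N/C(=N\C#N)NC1c1ccco1` awaits measurement in this assay. Its difference from compound 2 is furan-2-yl in place of thiophen-3-yl on a saturated ring carbon. Compound 1 and compound 3 carry furan-2-yl and phenyl on the same carbon and sit within the scatter of each other, so no step beyond the scatter is expected; a small drop is estimated, a number 7 percentage points lower from compound 2 to compound 4 (within the scatter). Compound 4 is expected to give 22%, between 10% and 34%.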

Compound 4, a percentage reported as inhibition, at one concentration (the size of the read-out at that concentration, not a potency): 27%
Estimate against measurement, compound 4: 5 percentage points below; low and high end bracket the measured number.
By their numbers in this assay, from the lowest: compounds 1, 3, 4 and 2 (each within the scatter of the next, the first and the last beyond it).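

With the ethyl ester held constant, furan-2-yl in place of thiophen-3-yl on the saturated ring carbon gives, in this assay, a number 2 percentage points lower from compound 2 to compound 4 (within the scatter). Among the compounds shown here, this is the first step read at this position, and it shows that this exchange of one five-membered aromatic ring with 1 hetero atom for another does not separate the two compounds. The step changes both the hetero atom and the ring's point of attachment, and the two changes cannot be told apart here; no measurement at hand bears on this result.

On these data alone, whether an amine or a carboxylic acid on the aromatic ring would shift the read-out remains open. So does the effect of a longer chain in place of the ethoxycarbonyl group.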